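Aryl swap from compound 2 to compound 3

The compounds below may be only part of what the source reports. "The series", "measured", "known", "first", "only" and "open" are said of these compounds alone.

Of the compounds shown here, two have numbers so far. In a functional assay on DU-145 cells (Homo sapiens) for inhibition, read by trypan blue exclusion, with a stated time of 96 h (a higher number here means a weaker inhibitor of growth, a lower number a stronger inhibitor of growth), compound 1 (`Cc1ccc(CS(=O)(=O)/C(=C/c2cc(C)cc(C)c2)C(=O)c2ccc(Cl)cc2)cc1`) gives 10000 nM, and compound 2 (`COc1ccccc1/C=C(\C(=O)c1ccc(Cl)cc1)S(=O)(=O)Cc1ccc(Cl)cc1`) gives 25000 nM. Compound 2 therefore holds the higher of the two numbers, and its gap to compound 1 lies beyond the scatter.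

Compound 3 (`Cc1cc(C)cc(/C=C(\C(=O)c2ccc(Cl)cc2)S(=O)(=O)Cc2ccc(Cl)cc2)c1`) has not yet been measured in this assay. It departs from compound 2 in one place: 3,5-dimethylphenyl in place of 2-methoxyphenyl on a double-bonded chain carbon bound to a double-bonded chain carbon.

Within the data shown here, no measured pair isolates this change, so any step remains an expectation resting on thin evidence. Among the measured compounds shown here, the only guide is compound 1, which also carries 3,5-dimethylphenyl and gives 10000 nM. A modest move towards a lower number is therefore expected, and a result within the scatter of compound 2 would not be surprising. The expected step is a 2.5-fold lower number from compound 2 to compound 3 (0.40 log units; beyond the scatter). Compound 3 is estimated at 10000 nM, with an expected range of 3000 nM to 30000 nM.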

Compound 3, concentration for 50% growth inhibition: 1000 nM
The estimate for compound 3 lay 10-fold (1.00 log units) above the measured number; measured number outside the range, below it.
By their numbers in this assay, from the lowest: compound 3; then compound 1; then compound 2.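

In this assay, the group on a double-bonded chain carbon bound to a double-bonded chain carbon now has a matched comparison: 3,5-dimethylphenyl in place of 2-methoxyphenyl gives a 25-fold lower number from compound 2 to compound 3 (1.40 log units; beyond the scatter) and shows that this one place alone can carry a large change in growth inhibition. The swap keeps 8 heavy atoms and one six-membered aromatic ring of carbon only, while the count of hydrogen-bond acceptors falls from 1 to 0. Chloro in place of methyl on an aromatic carbon gives a 10-fold lower number from compound 1 to compound 3 (1.00 log units; beyond the scatter) and shows that, with 3,5-dimethylphenyl held constant, a second place also moves the number beyond the scatter.

Nothing measured here accounts for either step.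

The compounds shown do not separate the loss of 2-methoxy from the gain of the two methyl groups, a question that plain phenyl, 3-methylphenyl or 3,5-dimethoxyphenyl at this place would address under the same chloro substitution as in compound 3.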